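Piperazine to Morpholine Amide: Expected Paw Edema Inhibition

The source may hold more compounds than are shown below. What is called first, only, known or untested is meant among the compounds shown, and "the series" means these compounds.

Compound 1 `COc1cc2c(cc1OC)C(CC(N)=O)CC2`: 27.8%
Compound 2 `CCNC(=O)CC1CCc2cc(OC)c(OC)cc21`: 20.4%
Compound 3 `COc1cc2c(cc1OC)C(CC(=O)N1CCNCC1)CC2`: 33.3%

In a functional assay on the whole organism (strain Wistar) for inhibition, with Rattus norvegicus as the target, read by paw edema, with stated times of 60 min and 6 h, at a dose of 100 mg/kg by the oral route (on this read-out higher numbers stand for more inhibition at the one dose given (going by the name of the read-out) and lower numbers for less inhibition), compound 3 gives the highest of the three numbers, with 33.3%. For the measured compounds named here, its step from compound 1 is small, a number 5.5 percentage points higher from compound 1 to compound 3 (within the scatter), while a number 12.9 percentage points higher from compound 2 to compound 3 (beyond the scatter) is the only step in the set that goes beyond the scatter. The step of a number 7.4 percentage points lower from compound 1 to compound 2 (within the scatter) stays within the scatter. Compound 4 `COc1cc2c(cc1OC)C(CC(=O)N1CCOCC1)CC2` is not yet measured in this assay. It differs from compound 3 in one place: morpholin-4-yl in place of piperazin-1-yl on a carbonyl carbon. Going by the values given here, the steps that bear on this change are those that vary the group on the carbonyl carbon, namely a number 5.5 percentage points higher from compound 1 to compound 3 (within the scatter) and a number 12.9 percentage points higher from compound 2 to compound 3 (beyond the scatter), and both are modest at most. Since every change of the amide substituent seen so far moved the read-out by little, a step within the scatter, or a slight drop, is expected in this assay. Compound 4 is therefore estimated at 28%, with a range from 15% to 40%. This estimate means a step of a number 5.3 percentage points lower from compound 3 to compound 4 (within the scatter), which is expected to stay within the usual scatter.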

Compound 4, a percentage reported as inhibition, in the whole organism at one dose (the size of the read-out at that dose, not a potency): 14.8%
For compound 4 the middle estimate is 13.2 percentage points above the measured one, and the stated range ends above it.
By their numbers in this assay, from the lowest: compounds 4, 2, 1 and 3 (each within the scatter of the next, the first and the last beyond it).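

Two rings of the same size on the carbonyl carbon do not behave alike in this assay: morpholin-4-yl in place of piperazin-1-yl gives a number 18.5 percentage points lower from compound 3 to compound 4 (beyond the scatter) and thus a step beyond the scatter, where the counts differ only in one nitrogen exchanged for oxygen and one hydrogen-bond donor lost. Against the open amides the same group gives a number 13 percentage points lower from compound 1 to compound 4 (beyond the scatter) but only a number 5.6 percentage points lower from compound 2 to compound 4 (within the scatter) and so a ring at this position does not in itself set the read-out, since compound 3 and compound 4 both carry one. Nothing at hand accounts for the gap between these two rings.

The compounds shown leave open whether the donor on piperazin-1-yl is what counts, which a 4-methylpiperazin-1-yl or a piperidin-1-yl on the same carbonyl carbon would address. They also leave open how a carboxylic acid would read in place of the amide.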